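The compounds below may be only part of what the source reports. "The series", "measured", "known", "first", "only" and "open" are said of these compounds alone.

Among the measured compounds shown here, in a functional assay on HepG2 cells (Homo sapiens) for antiproliferative activity, read by MTT assay, with a stated time of 48 h (a lower number here means a stronger inhibitor, a higher number a weaker inhibitor), compound 3 (`COc1ccc(CN(C(=O)Cn2cc(CSC3=NCCS3)nn2)c2cc(OC)c(OC)c(OC)c2)cc1`) gives 25000 nM, the highest of the three numbers so far. Compound 1 (`COc1ccc(CN(C(=O)Cn2cc(COc3cc(=O)oc4ccccc34)nn2)c2cc(OC)c(OC)c(OC)c2)cc1`) gives 6250 nM, and compound 2 (`COc1ccc(CN(C(=O)Cn2cc(COc3ccc4ccc(=O)oc4c3)nn2)c2cc(OC)c(OC)c(OC)c2)cc1`) gives 1300 nM. The next change leads to compound 4 (`COc1ccc(CN(C(=O)Cn2cc(CSc3nncs3)nn2)c2cc(OC)c(OC)c(OC)c2)cc1`): a group of 5 heavy atoms (2 carbon, 2 nitrogen, 1 sulfur; one five-membered aromatic ring with 3 hetero atoms) in place of a group of 5 heavy atoms (3 carbon, 1 nitrogen, 1 sulfur; one five-membered non-aromatic ring with 2 hetero atoms), on a sulfur. The sulfur stays, and a five-membered aromatic ring, 1,3,4-thiadiazol-2-yl, replaces a five-membered non-aromatic ring.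

For the measured compounds named here, no measured step makes this exchange directly. The nearest evidence is the replacement of a larger group on the saturated chain carbon: a 4.0-fold higher number from compound 1 to compound 3 (0.60 log units; beyond the scatter) and a 19-fold higher number from compound 2 to compound 3 (1.28 log units; beyond the scatter). In addition, a 4.8-fold lower number from compound 1 to compound 2 (0.68 log units; beyond the scatter) shows that a swap between two groups with aromatic rings can itself move the number beyond the scatter. Compound 1 and compound 2, both lower than compound 3, carry aromatic rings at this end, but three compounds give thin support for any trend.

A modest move to a lower number is therefore expected, with the estimated step being a 2.5-fold lower number from compound 3 to compound 4 (0.40 log units; beyond the scatter). The estimated value for compound 4 is 10000 nM, with an expected range of 3500 nM to 30000 nM.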

Compound 4, half-maximal inhibitory concentration: 38600 nM
The estimate for compound 4 lay 3.9-fold (0.59 log units) below the measured number; the measured number lies above the stated range.
By their numbers in this assay, from the lowest: compound 2; then compound 1; then compounds 3 and 4 (each within the scatter of the next).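

In this assay, the exchange on a sulfur whose other neighbour is a saturated chain carbon gives a 1.5-fold higher number from compound 3 to compound 4 (0.19 log units; within the scatter), so 1,3,4-thiadiazol-2-yl and the non-aromatic ring it replaces cannot be told apart here, and an aromatic ring at this end does not by itself carry the lower numbers seen earlier. The larger group exchanges remain clear, with a 30-fold higher number from compound 2 to compound 4 (1.47 log units; beyond the scatter) and a 6.2-fold higher number from compound 1 to compound 4 (0.79 log units; beyond the scatter), and the link between aromatic rings and lower numbers now has compound 4 as an exception. No measurement offered here accounts for these differences.

From the compounds shown here alone, in these steps the linking atom and the size of the group change together, so their separate contributions stay open. Also open, going by these compounds, is what an amine or a carboxylic acid would give on this sulfur in place of 1,3,4-thiadiazol-2-yl.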